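The compounds below may be only part of what the source reports. "The series", "measured", "known", "first", "only" and "open" are said of these compounds alone.

Compound 1 `CN(C(=O)C(C)(C)C)c1ccc2[nH]c(-c3n[nH]c4ccccc34)cc2n1` gives 18000 nM in a functional assay on HCT-116 cells (Homo sapiens) for antiproliferative activity, read by MTT assay, with a stated time of 72 h; on this read-out higher numbers stand for weaker inhibition and lower numbers for stronger inhibition. Compound 2 `COc1ccc(C(=O)N(C)c2ccc3[nH]c(-c4n[nH]c5ccccc45)cc3n2)cc1`, which in this assay gives 29500 nM, is linked to it by a 1.6-fold higher number from compound 1 to compound 2 (0.21 log units; within the scatter), so the two numbers sit within the scatter of each other and compound 2 is not set apart from compound 1. Compound 3 `COc1ccc(NC(=O)N(C)c2ccc3[nH]c(-c4n[nH]c5ccccc45)cc3n2)cc1` carries (4-methoxyphenyl)amino in place of 4-methoxyphenyl on a carbonyl carbon. Going by the values given here, the one measured step exchanged a group on the same carbonyl carbon and moved the number little; no measured step tests an added amino link. Compound 3 is expected to give about 30000 nM, between 10000 nM and 90000 nM. The expected step of a 1.0-fold higher number from compound 2 to compound 3 (0.01 log units; within the scatter) stays within the scatter.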

Compound 3, half-maximal inhibitory concentration: 63 nM
Beside the measured number, compound 3's estimate is 480-fold (2.68 log units) above it; measured number outside the range, below it.
By their numbers in this assay, from the lowest: compound 3; then compounds 1 and 2 (each within the scatter of the next).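

In this assay, the carbonyl carbon whose other neighbour is the amide-type nitrogen turns out to be highly sensitive: (4-methoxyphenyl)amino in place of 4-methoxyphenyl gives a 470-fold lower number from compound 2 to compound 3 (2.67 log units; beyond the scatter), although the earlier exchange there stayed within the scatter. The same group in place of tert-butyl gives a 290-fold lower number from compound 1 to compound 3 (2.46 log units; beyond the scatter), so the large drop appears from either starting group. Since 4-methoxyphenyl is kept, the step from compound 2 to compound 3 comes with the added amino link. No evidence is available on the reason for this step. From the compounds shown here alone, whether an oxygen link or an N-methylamino link would serve like the amino link remains open.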